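Chlorophenyl isomer swap with cytotoxicity expected unchanged

The source may hold more compounds than are shown below. What is called first, only, known or untested is meant among the compounds shown, and "the series" means these compounds.

Compound 2 `Cn1c(-c2ccccc2Cl)cnc1NC(=O)c1ccc(F)cc1` is a member of a small set examined in a toxicity assay on THP-1 cells (Homo sapiens) for inhibition; a higher number here means that more compound is tolerated, a lower number that less compound is tolerated. In this assay compound 2 gives > 50000 nM, which is a limit of the assay rather than a number. Compound 1 `Cn1c(-c2ccccc2Cl)cnc1NC(=O)c1ncc[nH]1` carries 1H-imidazol-2-yl on the carbonyl carbon. In this assay compound 1 gives > 50000 nM, again a limit. Among the compounds with values here, the one measured step, a step that the two limits leave unreadable from compound 1 to compound 2, has both ends at limits and so gives no size. Compound 3 `COc1ccc(-c2cnc(NC(=O)c3ccccc3Br)n2C)cc1` is the third member of the set. In this assay compound 3 gives > 100000 nM, also a limit. Within the data shown here, all three values shown thus sit at limits, the limit of > 50000 nM in this assay, at which 2 of the 3 values shown sit, and (the limit of > 100000 nM in this assay, at which 1 of the 3 values shown sits), and no compound in the set shows a readable half-maximal cytotoxic concentration.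

Compound 4 `Cn1c(-c2cccc(Cl)c2)cnc1NC(=O)c1ccc(F)cc1` differs from compound 2 by 3-chlorophenyl in place of 2-chlorophenyl on an aromatic carbon. Among the measured compounds shown here, no measured step bears on this change, and the sole step in the set cannot be read. With every measured compound tolerated up to its limit, compound 4 is expected to behave alike, so that the expected step that the limit leaves unreadable from compound 2 to compound 4 stays within the scatter. Compound 4 is therefore expected to give 80000 nM in this assay, within a range from 40000 nM to 200000 nM, and most likely to be reported again only as a limit.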

Compound 4, half-maximal cytotoxic concentration: > 50000 nM
Compound 4 gave a limit, no number; the forecaster's own chance of this, stated with the estimate: 85%; the middle value is on the limit's open side.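

In this assay compound 4 gives > 50000 nM, a limit and not a number. Compound 2 also sits at a limit, so the step between compound 2 and compound 4 cannot be read. The compounds shown leave open where the half-maximal cytotoxic concentration of any of them lies.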